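Amino in Place of Nitro Across Two Related Pairs

The source may report more compounds than this note shows. Statements on the series, on what has been measured and on what is new or still open speak of the compounds shown alone.

Four compounds are considered for their effect in a functional assay on MDA-MB-468 cells (Homo sapiens) for antiproliferative activity, read by MTT assay, with a stated time of 72 h; a higher number here means a weaker inhibitor, a lower number a stronger inhibitor. Compound 1 `COc1ccc(NC(=O)c2cc(OC)c(OC)c(OC)c2)cc1[N+](=O)[O-]` gives 2900 nM in this assay. Compound 2 `COc1ccc(NC(=O)c2cc(OC)c(OC)c(OC)c2)cc1N` differs from compound 1 by amino in place of nitro on an aromatic carbon. In this assay compound 2 gives 2000 nM. The step of a 1.5-fold lower number from compound 1 to compound 2 (0.16 log units; within the scatter) is thus a small one. Compound 3 `COc1ccc(OC(=O)c2cc(OC)c(OC)c(OC)c2)cc1[N+](=O)[O-]` reaches only a limit of the assay in this assay, where it gives > 100000 nM. This is the limit of > 100000 nM in this assay, at which 1 of the 3 values shown sits. How the core of compound 3 differs from that of compound 1 is not broken down here. Compound 4 `COc1ccc(OC(=O)c2cc(OC)c(OC)c(OC)c2)cc1N` has not yet been measured; it differs from compound 3 by amino in place of nitro on an aromatic carbon, the same change that separates compound 1 from compound 2, made at a place described in the same words. Since the measured step of a 1.5-fold lower number from compound 1 to compound 2 (0.16 log units; within the scatter) stayed within the scatter, compound 4 is expected to stay close to the limit seen for its parent, with an expected step of a number no higher from compound 3 to compound 4 (the limit leaves the size open). In this assay compound 4 is therefore estimated at 100000 nM, between 30000 nM and 300000 nM.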

Compound 4, half-maximal inhibitory concentration: > 100000 nM
Compound 4: only a limit was reported; the forecaster's own chance of this, stated with the estimate: 70%; the middle value lies on the limit itself.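

For compound 3 and compound 4 alike, the result in this assay is a limit and not a number, so no step between them can be read: the limit of > 100000 nM in this assay, at which 2 of the 4 values shown sit.

The compounds shown leave open whether amino in place of nitro changes the antiproliferative activity at all on the core of compound 3.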